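Flipping One Stereocentre in a Thiosemicarbazide-Free Pyrazoline Series

The source may report more compounds than this note shows. Statements on the series, on what has been measured and on what is new or still open speak of the compounds shown alone.

Measured so far:
- compound 1, `Cc1ccc(C2=NN(C(N)=S)[C@H](c3ccc(Cl)cc3)C2)cc1`: 1 nM
- compound 2, `NC(=S)N1N=C(c2ccc(F)cc2)C[C@@H]1c1ccc(Cl)cc1`: 1400 nM

Of the compounds shown here, two have been tested in an assay on mitochondria for inhibition of Amine oxidase [flavin-containing] B (Bos taurus); a lower number here means a stronger inhibitor, a higher number a weaker inhibitor. Compound 1 gives 1 nM in this assay, while compound 2 gives 1400 nM, the higher of the two numbers and far beyond the scatter; the pair differ in more than one place, so the numbers alone cannot be split into separate causes.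

Compound 3, `NC(=S)N1N=C(c2ccc(F)cc2)C[C@H]1c1ccc(Cl)cc1`, is the next compound. Relative to compound 2, (the two compounds have the same atoms and bonds and differ only in configuration as drawn: 1 of 1 stereo elements differ; a stereocentre at a saturated ring carbon is drawn R in compound 2 and S in compound 3). Nothing else changes.

Going by the values given here, no measured pair shows what such a flip does here. Still, the wide gap between compound 1 at 1 nM and compound 2 at 1400 nM leaves room for configuration to matter, and a change in configuration alone is expected to move the number in this assay well beyond the scatter, most likely downward. The step from compound 2 to compound 3 is estimated at a 47-fold lower number from compound 2 to compound 3 (1.67 log units; beyond the scatter). Compound 3 is expected to give about 30 nM, within a range of 2 nM to 500 nM.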

Compound 3, inhibition constant: 2400 nM
Estimate against measurement, compound 3: 80-fold (1.90 log units) below; measured number above the stated range.
By their numbers in this assay, from the lowest: compound 1; then compounds 2 and 3 (each within the scatter of the next).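

In this assay, flipping the stereocentre at the saturated ring carbon gives a 1.7-fold higher number from compound 2 to compound 3 (0.23 log units; within the scatter), so with fluoro on the aromatic ring, this flip makes no readable difference. The large change comes instead with the other single-place comparison, fluoro in place of methyl on an aromatic carbon, which gives a 2400-fold higher number from compound 1 to compound 3 (3.38 log units; beyond the scatter). Reading the flip as a clean test of configuration alone rests on one point: the fact that compounds 2 and 3 differ only in the configuration as drawn

Whether the same flip matters when methyl is present remains open, as the compounds shown carry the methyl group in one configuration only. Also open, from the compounds shown here alone, is how other groups on that aromatic carbon, such as methoxy or an ethyl group, would read in this assay.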